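Cyclohexylmethyl for Cyclobutyl: Expected Tolerance in Liver Cells

The source may report more compounds than this note shows. Statements on the series, on what has been measured and on what is new or still open speak of the compounds shown alone.

Of the compounds shown here, two sharing one core have been tested in an ADME assay on Huh-7 cells (Homo sapiens) for cytotoxicity, with a stated time of 72 h; a higher number here means that more compound is tolerated, a lower number that less compound is tolerated. Compound 1 `CC(C)CCn1nc(-c2ccn(C)c2)c(O)c(C2=NS(=O)(=O)c3cc(NS(C)(=O)=O)ccc3N2)c1=O` carries an isopentyl chain on the ring nitrogen and a methylpyrazole on the neighbouring position. In this assay compound 1 reaches only the limit of the measurement, > 1000 nM. Compound 2 `CS(=O)(=O)Nc1ccc2c(c1)S(=O)(=O)N=C(c1c(O)c(-c3cccs3)nn(CC3CCC3)c1=O)N2` carries a cyclobutylmethyl chain and a thiophene instead. In this assay compound 2 likewise reaches only the limit, > 1000 nM. Both values therefore sit at the same limit (the limit of > 1000 nM in this assay, at which 2 of the 2 values shown sit), and no real difference between them can be read.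

Compound 3 `CS(=O)(=O)Nc1ccc2c(c1)S(=O)(=O)N=C(c1c(O)c(-c3cccs3)nn(CCC3CCCCC3)c1=O)N2` is not yet measured. It differs from compound 2 in one place: cyclohexylmethyl in place of cyclobutyl on a saturated chain carbon bound to an aromatic nitrogen. Going by the values given here, no measured step exists for this kind of change, so there is no evidence that it moves tolerance in either direction. The step from compound 2 to compound 3 is expected to be small, a step that the limit leaves unreadable from compound 2 to compound 3, most likely within the scatter. For compound 3 the estimated value is 1500 nM, with a range from 500 nM to 5000 nM, and the assay may again report only a limit.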

Compound 3, half-maximal cytotoxic concentration: > 17000 nM
Compound 3: a limit, no number; the forecaster's own chance of this, stated with the estimate: 65%; middle value at least 11-fold (1.05 log units) from the limit.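

Going by these compounds alone, compound 2 and compound 3 both give only limits in this assay, so no step between them can be read. The compounds shown leave open whether cyclohexylmethyl in place of cyclobutyl on a saturated chain carbon bound to an aromatic nitrogen changes tolerance at all, and what concentration compound 1, compound 2 or compound 3 would take to harm the cells.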